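Replacing one ring group on compound 1

The compounds below may be only part of what the source reports. "The series", "measured", "known", "first", "only" and "open" are said of these compounds alone.

Compound 1 `CCC/N=C1\S/C(=C\c2ccc(O)c(Cl)c2)C(=O)N1C1CCS(=O)(=O)CC1` gives 2.6
Compound 2 `CCC/N=C1\S/C(=C\c2ccc(O)c(C(F)(F)F)c2)C(=O)N1c1ccccc1C` gives 3.8

In a physicochemical assay for lipophilicity, read by HPLC, at pH 7.4 (a lower number here means a more polar compound, a higher number a more lipophilic compound), compound 1 stands at 2.6 and is the lower of the two measured compounds, with a gap to compound 2 beyond the scatter. Compound 3 `CCC/N=C1\S/C(=C\c2ccc(O)c(Cl)c2)C(=O)N1c1ccccc1O` keeps the core of compound 1 and has 2-hydroxyphenyl in place of 1,1-dioxothian-4-yl on an amide-type nitrogen in a ring in the structure. Among the compounds with values here, no measured pair shows this change alone. Compound 2 (3.8) also has an aromatic ring of carbon only at that place, although it differs elsewhere too. An upward move beyond the scatter is expected, an estimated a number 0.70 log units higher from compound 1 to compound 3 (beyond the scatter) in this assay (a rough expectation). Compound 3 is estimated at 3.3 (range 2.8 to 3.8).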

Compound 3, distribution coefficient: 2.7
Compound 3: middle estimate off by 0.60 log units, on the high side; the measured number lies below the stated range.
By their numbers in this assay, from the lowest: compounds 1 and 3 (each within the scatter of the next); then compound 2.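

With 2-hydroxyphenyl in place of 1,1-dioxothian-4-yl on an amide-type nitrogen in a ring, this assay gives a number 0.10 log units higher from compound 1 to compound 3 (within the scatter). Within the data shown here, this is the first pair that differs in one place only, and it shows that these two quite different groups cannot be told apart by this measurement at this position. No measurement shown here offers an explanation for the match.

The compounds shown leave open how a plain phenyl or a piperidine ring would read at this nitrogen. They also leave open whether the same swap gives a similar step when trifluoromethyl replaces the chlorine of the core.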